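The compounds below may be only part of what the source reports. "The series", "measured", "known", "first", "only" and "open" are said of these compounds alone.

Measured so far:
compound 1, `O=C(CSc1nnc(-c2ccncc2)o1)N/N=C/c1ccccc1`, 17300 nM in a functional assay on HepG2 cells (Homo sapiens) for cytotoxicity, read by MTT assay, with a stated time of 48 h; on this read-out lower numbers stand for stronger inhibition and higher numbers for weaker inhibition
compound 2, `O=C(CSc1nnc(-c2ccncc2)o1)N/N=C/c1cc(Br)cc(Br)c1O`, 6540 nM in this assay

Compound 2 stands at the lower of the two numbers: the step from its parent is a 2.6-fold lower number from compound 1 to compound 2 (0.42 log units; beyond the scatter), a change that lies beyond the usual scatter of this read-out. Both compounds share the same core and differ only in the ring attached to the carbon that carries a double bond to nitrogen.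

Compound 3, `O=C(CSc1nnc(-c2ccncc2)o1)N/N=C/c1ccc(O)c(O)c1`, continues this series with a further change at that same ring: 3,4-dihydroxyphenyl in place of 3,5-dibromo-2-hydroxyphenyl on a carbon with a double bond to nitrogen. Within the data shown here, only one measured step bears on this position, the move from compound 1 to compound 2, and it shows that replacing plain phenyl with a hydroxyl-bearing dibromo ring gives a modestly lower number. Among the measured compounds shown here, compound 3 keeps hydroxyl groups on the ring but gives up both bromines, so the one comparison in hand points in neither direction with confidence. The number for compound 3 in this assay is therefore expected to fall between those of its two neighbours, a step of a 1.5-fold higher number from compound 2 to compound 3 (0.18 log units; within the scatter) that is within the scatter. For compound 3 the estimate is 10000 nM, with a likely range from 3000 nM to 35000 nM.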

Compound 3, half-maximal inhibitory concentration: 760 nM
The estimate for compound 3 lay 13-fold (1.12 log units) above the measured number, outside the stated range (below it).
By their numbers in this assay, from the lowest: compound 3; then compound 2; then compound 1.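

In this assay, the group on the carbon with a double bond to nitrogen matters much more than the first step suggested: 3,4-dihydroxyphenyl in place of phenyl gives a 23-fold lower number from compound 1 to compound 3 (1.36 log units; beyond the scatter), a far larger drop than the dibromo ring produced. Bromine is also not required for a low number at this position, since replacing 3,5-dibromo-2-hydroxyphenyl with the bromine-free 3,4-dihydroxyphenyl gives an 8.6-fold lower number from compound 2 to compound 3 (0.93 log units; beyond the scatter), and so the ring with two hydroxyl groups ranks lowest of the three. No supporting measurement is available to explain why this ring gives the lowest number.

That last swap removes both bromines and also changes the number and placement of the hydroxyl groups, so the compounds shown cannot separate the contribution of each change. As far as these compounds go, it remains open whether both hydroxyl groups are needed, and how this position would respond to a ring carrying a single hydroxyl group, a methoxy group, an amine or a carboxylic acid.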